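Hydroxyl position on the phenyl ring: compound 3 outlook

A few compounds are considered here, and "the series" means these few. Any claim that something is new, unique, unknown or untested is made for them only; others in the source may bear on it.

Compound 2 `O=C1CSC(c2cccc(O)c2)N1CCN1CCCCC1` gives the higher of the two values measured in an ADME assay on Vero cells (Chlorocebus sabaeus) for cytotoxicity, read by neutral red uptake, tested at 394 ug/mL (a lower number here means a stronger effect, a higher number a weaker effect of the compound at the concentration tested), at 100%. Compound 1 `COc1ccc(C2SCC(=O)N2CCN2CCCCC2)cc1` gives 73% in this assay, a gap beyond the usual scatter of this measurement. Compound 3 `O=C1CSC(c2ccc(O)cc2)N1CCN1CCCCC1` has not yet been measured; it differs from compound 2 by 4-hydroxyphenyl in place of 3-hydroxyphenyl on a saturated ring carbon. Going by the values given here, no step of this kind has been measured, so only a small shift is expected, within the scatter and in no certain direction; the expected step is a number 8 percentage points lower from compound 2 to compound 3 (within the scatter). Compound 3 is expected to give 92% in this assay, between 72% and 100%.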

Compound 3, a percentage reported as activity, at one concentration (the size of the read-out at that concentration, not a potency): 76%
The estimate for compound 3 lay 16 percentage points above the measured number, within the range that was stated.
By their numbers in this assay, from the lowest: compounds 1 and 3 (each within the scatter of the next); then compound 2.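

Moving the hydroxyl matters in this assay: 4-hydroxyphenyl in place of 3-hydroxyphenyl on a saturated ring carbon gives a number 24 percentage points lower from compound 2 to compound 3 (beyond the scatter), although the two compounds have the same atoms. With the hydroxyl group's position held, hydrogen in place of methyl on an oxygen on an aromatic ring gives a number 3 percentage points higher from compound 1 to compound 3 (within the scatter), so this change shows no clear effect. No measurement at hand explains either step. Open, as far as these compounds go, is how an amine or a carboxylic acid in place of the hydroxyl would read in this assay.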